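Chalcone series on the shared core: halogenated aryl variation

The source may hold more compounds than are shown below. What is called first, only, known or untested is meant among the compounds shown, and "the series" means these compounds.

Compound 1 `CC1(C)Cc2c(OCc3ccccc3)ccc(C(=O)/C=C/c3ccc(Cl)cc3Cl)c2O1` carries a 2,4-dichlorophenyl on the double-bonded chain. In a functional assay on PC-3 cells (Homo sapiens) for antiproliferative activity, read by MTT assay, with a stated time of 48 h (on this read-out higher numbers stand for weaker inhibition and lower numbers for stronger inhibition), compound 1 returns only > 100000 nM, which is a limit of the assay and not a number. Compound 1 therefore stands at the limit of > 100000 nM in this assay, at which 2 of the 3 values shown sit, rather than at any measured value. Compound 3 `CC1(C)Cc2c(ccc(C(=O)/C=C/c3ccccc3)c2OCc2ccccc2)O1`, the plain phenyl analogue, likewise gives > 100000 nM in this assay, again a limit and not a number. Among the measured compounds shown here, compound 2 `CC1(C)Cc2c(ccc(C(=O)/C=C/c3cn(-c4ccccc4)nc3-c3ccc([N+](=O)[O-])cc3)c2OCc2ccccc2)O1` is the only member with a number: in this assay compound 2 gives 62300 nM.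

Compound 4 `CC1(C)Cc2c(OCc3ccccc3)ccc(C(=O)/C=C/c3ccc(Br)cc3)c2O1` is the next point in the row. The change from compound 1 is 4-bromophenyl in place of 2,4-dichlorophenyl on a double-bonded chain carbon bound to a double-bonded chain carbon; cut one bond further out it reads 2-(2,4-dichlorophenyl)ethenyl to 2-(4-bromophenyl)ethenyl. For the measured compounds named here, no measured pair in this set separates the effect of one halogen pattern from another on the aryl of the chain, so the step has no measured precedent. Given that compound 1 and compound 3 both sit at the limit, the expectation is that the step from compound 1 to compound 4 is a number no higher from compound 1 to compound 4 (the limit leaves the size open), that is, nothing beyond the scatter. Compound 4 is accordingly expected near 100000 nM, within 30000 nM to 300000 nM, with a fair chance that this assay again reports only a limit.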

Compound 4, half-maximal inhibitory concentration: > 100000 nM
Compound 4 ended at the assay's limit; the forecaster's own chance of this, stated with the estimate: 65%; the middle value sits exactly at the limit.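

In this assay compound 1 and compound 4 both end at a limit and not at a number, so no step between them can be read; the series now stands at: the limit of > 100000 nM in this assay, at which 3 of the 4 values shown sit.

Still open, from the compounds shown here alone, is whether 4-bromophenyl and 2,4-dichlorophenyl on the shared core differ at all in this assay.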